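Aryl amide variation in the shared series, next step

A few compounds are considered here, and "the series" means these few. Any claim that something is new, unique, unknown or untested is made for them only; others in the source may bear on it.

Compound 1 `Cc1ccc(NC(=O)c2ccc(/N=N\c3c[nH]c4ccccc34)cc2)cc1` gives 42400 nM in a functional assay on MCF7 cells (Homo sapiens) for inhibition, read by MTT assay, with a stated time of 72 h; on this read-out higher numbers stand for weaker inhibition and lower numbers for stronger inhibition. Compound 2 `Cc1cccc(NC(=O)c2ccc(/N=N\c3c[nH]c4ccccc34)cc2)c1C` gives 106000 nM in this assay, and compound 3 `O=C(Nc1ccccc1Cl)c1ccc(/N=N\c2c[nH]c3ccccc23)cc1` gives 112000 nM. Compound 3 stands at the highest number of the three: its nearest neighbour is compound 2, with the pair differing by a 1.1-fold higher number from compound 2 to compound 3 (0.02 log units; within the scatter), and its furthest is compound 1, with a 2.6-fold higher number from compound 1 to compound 3 (0.42 log units; beyond the scatter).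

Compound 4 `Cc1ccc(NC(=O)c2ccc(/N=N\c3c[nH]c4ccccc34)cc2)c(C)c1` differs from compound 3 by 2,4-dimethylphenyl in place of 2-chlorophenyl on an amide-type nitrogen. Within the data shown here, two measured steps bear on this. Moving from 4-methylphenyl to 2,3-dimethylphenyl gave a 2.5-fold higher number from compound 1 to compound 2 (0.40 log units; beyond the scatter), and moving from 4-methylphenyl to 2-chlorophenyl gave a 2.6-fold higher number from compound 1 to compound 3 (0.42 log units; beyond the scatter), so both substitution changes at the amide aryl pushed the number up by a modest amount, while 2,3-dimethylphenyl and 2-chlorophenyl sat level with each other. Compound 4 carries a dimethylphenyl like compound 2 but also retains a 4-methyl feature present in compound 1, so its number is expected to fall between those two, most likely closer to compound 2.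

The step from compound 3 to compound 4 is therefore expected to be a 1.6-fold lower number from compound 3 to compound 4 (0.20 log units; within the scatter), downward but small. Compound 4 is estimated at 70000 nM in this assay, within a range of 30000 nM to 160000 nM.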

Compound 4, half-maximal inhibitory concentration: 87000 nM
Beside the measured number, compound 4's estimate is 1.2-fold (0.09 log units) below it, within the range that was stated.
By their numbers in this assay, from the lowest: compound 1; then compounds 4, 2 and 3 (each within the scatter of the next).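

Within this assay, the three groups with a substituent on this amide-type nitrogen's aryl ring remain indistinguishable: 2,4-dimethylphenyl in place of 2-chlorophenyl gives no change beyond the scatter (a 1.3-fold lower number from compound 3 to compound 4 (0.11 log units; within the scatter)), and 2,4-dimethylphenyl in place of 2,3-dimethylphenyl gives none either (a 1.2-fold lower number from compound 2 to compound 4 (0.09 log units; within the scatter)). Among these compounds, compound 4 also supplies the one single-methyl comparison in the set, since methyl in place of hydrogen on an aromatic carbon of the 4-methylphenyl group gives a modest rise (a 2.1-fold higher number from compound 1 to compound 4 (0.31 log units; beyond the scatter)), which leaves compound 1 as the strongest of the four, with compounds 2, 3 and 4 level at weaker numbers. No measurement in hand accounts for this difference between compound 1 and the other three.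

Still open, on these data alone, is how the number responds to unsubstituted phenyl, or to an amine or a carboxylic acid on this aryl ring, in place of the methyl and chlorine groups seen so far. Also open, as far as these compounds go, is whether the modest gap between 4-methylphenyl and the other aryl groups holds once the shared core is changed.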